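Anilide series: chain extension with a 4-chlorophenoxy tail

The compounds below may be only part of what the source reports. "The series", "measured", "known", "first", "only" and "open" are said of these compounds alone.

Within the data shown here, compound 2 `Cc1cc(C)c(NC(=O)C(C)(C)CCCCCc2ccccc2)c2c1CC(C)(C)O2` gives 120 nM in an assay for inhibition of acyl-CoA:cholesterol acyltransferase (Oryctolagus cuniculus), using microsomes (a higher number here means a weaker inhibitor, a lower number a stronger inhibitor), the higher of the two numbers measured so far; compound 1 `CCCCCCCCCCC(C)(C)C(=O)Nc1c(C)c(N)c(C)c2c1OC(C)(C)C2` gives 59 nM in this assay, which is the lower of the pair. Compound 3 `Cc1cc(C)c(NC(=O)C(C)(C)CCCCCCOc2ccc(Cl)cc2)c2c1CC(C)(C)O2` has not been measured; it differs from compound 2 by (4-chlorophenoxy)methyl in place of phenyl on a saturated chain carbon, six bonds along the chain from a carbonyl carbon. Among the measured compounds shown here, no pair of measured compounds shows this change, so the step from compound 2 to compound 3 is expected to be a moderate decrease in the number, a 2.0-fold lower number from compound 2 to compound 3 (0.30 log units; within the scatter), with an increase not ruled out. Compound 3 is estimated at 60 nM, with a range from 25 nM to 150 nM.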

Compound 3, half-maximal inhibitory concentration: 76 nM
Compound 3: middle estimate off by 1.3-fold (0.10 log units), on the low side, and the stated range covers the measured number.
By their numbers in this assay, from the lowest: compounds 1, 3 and 2 (each within the scatter of the next, the first and the last beyond it).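

In this assay, (4-chlorophenoxy)methyl in place of phenyl on a saturated chain carbon, six bonds along the chain from a carbonyl carbon, gives a 1.6-fold lower number from compound 2 to compound 3 (0.20 log units; within the scatter), so this position accepts the change with no shift beyond the scatter. The tail can therefore carry an ether oxygen and a chlorine without a clear loss or gain here. Nothing available explains this result.

The compounds shown do not separate the contribution of the oxygen from that of the chlorine, which an unsubstituted phenoxy tail would address. As far as these compounds go, how an amine or a carboxylic acid would read in place of the 4-chlorophenoxy group also remains open.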